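Taking the acetyl group off compound 3

The source may hold more compounds than are shown below. What is called first, only, known or untested is meant among the compounds shown, and "the series" means these compounds.

In an ADME assay on MT4 cells (Homo sapiens) for cytotoxicity, read by MTT assay, with a stated time of 4 days (a lower number here means that less compound is tolerated, a higher number that more compound is tolerated), compound 1 (`CC(=O)Nc1ccc2oc(-c3ccccc3)c(O)c(=O)c2c1`) gives 64700 nM, compound 2 (`Nc1ccc2oc(-c3ccccc3)c(O)c(=O)c2c1`) gives 217000 nM and compound 3 (`COc1c(-c2ccccc2)oc2ccc(NC(C)=O)cc2c1=O`) gives 200000 nM. Compound 3 is within the scatter of compound 2, and both lie beyond the scatter from compound 1, the lowest of the three. Compound 4 (`COc1c(-c2ccccc2)oc2ccc(N)cc2c1=O`) has not yet been measured. It differs from compound 3 in one place, with hydrogen in place of acetyl on a nitrogen on an aromatic ring, acetamido to amino (hydrogen in place of acetyl on a nitrogen on an aromatic ring). The same change has been measured once, a 3.4-fold higher number from compound 1 to compound 2 (0.53 log units; beyond the scatter), a modest step beyond the scatter. The other measured step, a 3.1-fold higher number from compound 1 to compound 3 (0.49 log units; beyond the scatter), adds the methyl on an oxygen on an aromatic ring that compound 3 and compound 4 both carry. The data do not show whether the two steps add up, so only part of the first is counted on. The expected change in this assay is therefore a 2.1-fold higher number from compound 3 to compound 4 (0.32 log units; beyond the scatter), modest and upward. Compound 4 is estimated at 420000 nM, with an expected range of 180000 nM to 900000 nM.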

Compound 4, half-maximal cytotoxic concentration: 126000 nM
Compound 4: middle estimate off by 3.3-fold (0.52 log units), on the high side; the whole stated range lies above it.
By their numbers in this assay, from the lowest: compounds 1, 4, 3 and 2 (each within the scatter of the next, the first and the last beyond it).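

In this assay, acetamido to amino gives a 1.6-fold lower number from compound 3 to compound 4 (0.20 log units; within the scatter) when the oxygen carries a methyl, so the step seen with hydrogen on that oxygen does not carry over: the same change on two cores in this assay, a 3.4-fold higher number (0.53 log units; beyond the scatter) from compound 1 to compound 2 and a 1.6-fold lower number (0.20 log units; within the scatter) from compound 3 to compound 4, 5.3-fold (0.73 log units) apart, beyond the scatter of two such steps. Methyl in place of hydrogen on the oxygen shows the same dependence on its partner, giving a 1.7-fold lower number from compound 2 to compound 4 (0.24 log units; within the scatter) when the nitrogen carries no acetyl: the same change on two cores in this assay, a 3.1-fold higher number (0.49 log units; beyond the scatter) from compound 1 to compound 3 and a 1.7-fold lower number (0.24 log units; within the scatter) from compound 2 to compound 4, 5.3-fold (0.73 log units) apart, beyond the scatter of two such steps. The two changes do not add up here: each alone gives a higher number than compound 1, yet compound 4, which carries both, is within the scatter of compound 2 and compound 3.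

Whether the low number of compound 1 needs acetamido and hydrogen on the oxygen together rests on these four compounds alone. On these data alone, how a longer acyl chain on that nitrogen or an ethyl on that oxygen would fit this pattern stays open.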